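Dimethylphenyl in Place of a Halogenated Phenyl Ring

The source may report more compounds than this note shows. Statements on the series, on what has been measured and on what is new or still open speak of the compounds shown alone.

Compound 3 `Cc1oc(-c2c(Cl)cccc2Br)nc1CN1CCC(C(=O)NCCCN2C[C@H](C)C[C@H](C)C2)CC1` was tested in an ADME assay on Huh7.5.1 cells (Homo sapiens) for cytotoxicity, read by ATP content, with a stated time of 48 h (on this read-out lower numbers stand for higher toxicity in this test and higher numbers for lower toxicity in this test), where compound 3 gives 12200 nM. Of the three measured compounds, compound 1 `Cc1ccccc1-c1nc(CN2CCC(C(=O)NCCCN3CCCCC3)CC2)c(C)o1` gives 18100 nM and compound 2 `Cc1ccccc1-c1nc(CN2CCC(C(=O)NCCCN3CC4CCCC(C4)C3)CC2)c(C)o1` gives 10900 nM; compound 3 lies between them, and both gaps stay within the scatter. For the measured compounds named here, the single step measured so far, a 1.7-fold lower number from compound 1 to compound 2 (0.22 log units; within the scatter), concerns the ring at the end of the chain and also stays within the scatter. Compound 4 `Cc1ccc(-c2nc(CN3CCC(C(=O)NCCCN4C[C@H](C)C[C@H](C)C4)CC3)c(C)o2)c(C)c1` differs from compound 3 in one place: 2,4-dimethylphenyl in place of 2-bromo-6-chlorophenyl on an aromatic carbon. Going by the values given here, no measured step touches this part of the molecule, so nothing points to a shift beyond the scatter. In this assay the expected step is a 1.0-fold lower number from compound 3 to compound 4 (0.01 log units; within the scatter). Compound 4 is therefore estimated at 12000 nM, between 5000 nM and 30000 nM.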

Compound 4, half-maximal cytotoxic concentration: 4110 nM
Compound 4: middle estimate off by 2.9-fold (0.47 log units), on the high side, outside the stated range (below it).
By their numbers in this assay, from the lowest: compound 4; then compounds 2, 3 and 1 (each within the scatter of the next).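

In this assay, for the compounds shown here, this aromatic carbon is the first place where a single change goes beyond the scatter: a 3.0-fold lower number from compound 3 to compound 4 (0.47 log units; beyond the scatter). Swapping 2-bromo-6-chlorophenyl for 2,4-dimethylphenyl keeps the group's heavy-atom count yet still gives higher toxicity in this test, so the identity of this group matters here. No measurement shown here accounts for the shift. On these data alone, it remains open whether losing the halogens or gaining the methyl groups carries the step. An unsubstituted phenyl ring on this carbon, with the rest of compound 3 kept, would help separate the two.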